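A few compounds are considered here, and "the series" means these few. Any claim that something is new, unique, unknown or untested is made for them only; others in the source may bear on it.

In a functional assay on A549 cells (Homo sapiens) for antiproliferative activity, read by MTT assay, with a stated time of 72 h (a lower number here means a stronger inhibitor, a higher number a weaker inhibitor), the measured compounds stand as follows:

compound 1 `CCCSc1nc(Cl)c2c(n1)N(Cc1ccccc1)C(C(=O)N1CCN(Cc3ccccc3)CC1)N2` gives 14400 nM
compound 2 `CCCSc1nc(Cl)c2c(n1)N(Cc1ccccc1)C(C(=O)O)N2` gives 10700 nM
compound 3 `CCCSc1nc(Cl)c2c(n1)N(CC1CCCCC1)C(C(=O)N1CCN(C)CC1)N2` gives 13200 nM

Compound 1 has the highest of the three numbers, but its distance to compound 3 and to compound 2 lies within the usual scatter of repeated measurements, so the three compounds cannot be told apart on these data.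

Compound 4 `CCCSc1nc(Cl)c2c(n1)N(Cc1ccccc1)C(C(=O)N1CCN(C)CC1)N2` is the next compound to be measured in this assay. It differs from compound 1 in one place: hydrogen in place of phenyl on a saturated chain carbon bound to an amine nitrogen in a ring. Going by the values given here, no measured pair shows this change on its own. The only related hint comes from compound 3, which carries the methyl on the same ring nitrogen but a different group on the core, and whose value sits close to that of compound 1.

The step from compound 1 to compound 4 is therefore expected to stay within the scatter, a 1.1-fold lower number from compound 1 to compound 4 (0.04 log units; within the scatter). Compound 4 is estimated at 13000 nM, with a range from 5000 nM to 35000 nM.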

Compound 4, half-maximal inhibitory concentration: 2800 nM
For compound 4 the middle estimate is 4.6-fold (0.67 log units) above the measured one; measured number below the stated range.
By their numbers in this assay, from the lowest: compound 4; then compounds 2, 3 and 1 (each within the scatter of the next).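

In this assay, the ring amine substituent proves to matter: hydrogen in place of phenyl on a saturated chain carbon bound to an amine nitrogen in a ring, read one bond further out as benzyl to methyl, gives a 5.1-fold lower number from compound 1 to compound 4 (0.71 log units; beyond the scatter). The methyl does not act alone, since phenyl in place of cyclohexyl on a saturated chain carbon bound to a nitrogen on an aromatic ring in a ring gives a 4.7-fold lower number from compound 3 to compound 4 (0.67 log units; beyond the scatter). The amide also counts, with 4-methylpiperazin-1-yl in place of hydroxy on a carbonyl carbon giving a 3.8-fold lower number from compound 2 to compound 4 (0.58 log units; beyond the scatter).

The compounds shown leave open whether an ethyl group or a free amine hydrogen on that ring nitrogen would match the methyl. Nothing available explains these steps.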